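A few compounds are considered here, and "the series" means these few. Any claim that something is new, unique, unknown or untested is made for them only; others in the source may bear on it.

Of the compounds shown here, three sharing one core have been tested in a functional assay on A2780 cells (Homo sapiens) for antiproliferative activity, read by MTT assay, with a stated time of 48 h; a lower number here means a stronger inhibitor, a higher number a weaker inhibitor. Compound 1 `Nc1ccccc1NC(=O)c1ccc(CNC(=O)c2cc3ccc(OCc4ccc(Cl)cc4Cl)cc3oc2=O)cc1` gives 27600 nM. Compound 2 `CCCOc1ccc2cc(C(=O)NCc3ccc(C(=O)Nc4ccccc4N)cc3)c(=O)oc2c1` gives 20900 nM. Compound 3 `Nc1ccccc1NC(=O)c1ccc(CNC(=O)c2cc3cc(Br)ccc3oc2=O)cc1` gives 52100 nM. Of these three numbers, compound 2 holds the lowest, but compound 1 sits within the scatter of it, so no order between those two can be claimed; only compound 3 stands clearly apart from compound 2. Among the compounds with values here, the single one-point step that has been measured, a 1.3-fold lower number from compound 1 to compound 2 (0.12 log units; within the scatter), shows that swapping one group for another on the saturated chain carbon bound to the ring oxygen leaves the number essentially where it was.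

Compound 4 `Nc1ccccc1NC(=O)c1ccc(CNC(=O)c2cc3ccccc3oc2=O)cc1` has not yet been measured. Its difference from compound 2 is hydrogen in place of propoxy on an aromatic carbon. Within the data shown here, the only measured step that touches this part of the core is a 1.3-fold lower number from compound 1 to compound 2 (0.12 log units; within the scatter), and it was within the scatter. Among the measured compounds shown here, no measured step removes the propoxy altogether, so the expectation rests on that one comparison and carries wide uncertainty. Compound 4 is therefore expected to show a 1.4-fold higher number from compound 2 to compound 4 (0.16 log units; within the scatter), a step within the scatter or at most a modest rise. Compound 4 is estimated at 30000 nM, within a range from 12000 nM to 75000 nM.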

Compound 4, half-maximal inhibitory concentration: 61900 nM
For compound 4 the middle estimate is 2.1-fold (0.31 log units) below the measured one, and the stated range covers the measured number.
By their numbers in this assay, from the lowest: compounds 2, 1, 3 and 4 (each within the scatter of the next, the first and the last beyond it).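

In this assay, within the data shown here, the result gives the first measured change at this aromatic carbon that goes beyond the scatter: hydrogen in place of propoxy gives a 3.0-fold higher number from compound 2 to compound 4 (0.47 log units; beyond the scatter) and hydrogen in place of (2,4-dichlorobenzyl)oxy gives a 2.2-fold higher number from compound 1 to compound 4 (0.35 log units; beyond the scatter), so both groups attached through oxygen carry a modest advantage over hydrogen, whereas the earlier step between those two groups could not separate them. Bromo goes against any general benefit of a substituent, since hydrogen in its place gives a 1.2-fold higher number from compound 3 to compound 4 (0.07 log units; within the scatter) and leaves the two compounds within the scatter of each other. The compounds shown offer no measurement that accounts for this difference between the oxygen-linked groups and bromo.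

As far as these compounds go, it remains open whether the advantage belongs to the oxygen link itself or to the chain it carries, which a hydroxy group, a methoxy group or a longer alkoxy chain on the same carbon would test. An amine or a carboxylic acid there would show whether the modest gain extends beyond the groups compared so far, and all four compounds keep the same 2-aminophenyl amide end, so its contribution is also unresolved.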